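The compounds below may be only part of what the source reports. "The series", "measured", "known", "first", "only" and "open" are said of these compounds alone.

Measured compounds in an ADME assay on NIH3T3 cells (Mus musculus) for cytotoxicity, read by MTT assay, with a stated time of 24 h; a higher number here means a weaker inhibitor, a lower number a stronger inhibitor:

- compound 1, `Cc1nnc(SCC(=O)N/N=c2/scc(-c3ccc(F)cc3)n2-c2ccccc2)s1`: compound 1 gives 383 ug/mL
- compound 2, `Cn1nnnc1SCC(=O)N/N=c1/scc(-c2ccc(F)cc2)n1-c1ccccc1`: compound 2 gives 113 ug/mL
- compound 3, `Cn1cnnc1SCC(=O)N/N=c1/scc(-c2ccc(F)cc2)n1-c1ccccc1`: compound 3 gives 65 ug/mL

Compound 2 stands second highest of the three numbers in this assay. Its nearest neighbour is compound 3, a 1.7-fold lower number from compound 2 to compound 3 (0.24 log units; within the scatter), a gap that cannot be read as a change. Its furthest neighbour is compound 1, a 3.4-fold lower number from compound 1 to compound 2 (0.53 log units; beyond the scatter). The third measured step, a 5.9-fold lower number from compound 1 to compound 3 (0.77 log units; beyond the scatter), likewise concerns the group on sulfur.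

Compound 4, `Cn1nnnc1SCC(=O)N/N=c1/scc(-c2ccc([N+](=O)[O-])cc2)n1-c1ccccc1`, is the unmeasured member. It differs from compound 2 by nitro in place of fluoro on an aromatic carbon. For the measured compounds named here, all three measured steps alter the methylated heteroaryl on sulfur; none alters the six-membered carbon ring, so none bears directly on this change, and the effect of exchanging fluoro for nitro here has no precedent. Going by the values given here, with no measured step to lean on, a change beyond the scatter is not expected in either direction: the expected step is a 1.0-fold lower number from compound 2 to compound 4 (0.01 log units; within the scatter). Compound 4 is estimated at 110 ug/mL in this assay, with a range from 45 ug/mL to 270 ug/mL.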

Compound 4, half-maximal inhibitory concentration: 167 ug/mL
Estimate against measurement, compound 4: 1.5-fold (0.18 log units) below; measured number inside the range.
By their numbers in this assay, from the lowest: compounds 3, 2 and 4 (each within the scatter of the next, the first and the last beyond it); then compound 1.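

For the compounds shown here, on the six-membered aromatic ring of carbon only, para to a large group, this is the first exchange, and in this assay 4-nitrophenyl in place of 4-fluorophenyl gives a 1.5-fold higher number from compound 2 to compound 4 (0.17 log units; within the scatter), which cannot be read as a change. With the 1-methyl-1H-tetrazol-5-yl group held on sulfur, this aromatic position has so far shown no step beyond the scatter, whereas replacing the 5-methyl-1,3,4-thiadiazol-2-yl group on sulfur does, as in a 5.9-fold lower number from compound 1 to compound 3 (0.77 log units; beyond the scatter). No measurement is available that would explain the result.

Only fluoro and nitro are shown at this place, both with the same group on sulfur. From the compounds shown here alone, whether an amine or a carboxylic acid here would stay within the scatter remains open, as does whether nitro behaves alike with the 4-methyl-4H-1,2,4-triazol-3-yl group on sulfur.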